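The source may report more compounds than this note shows. Statements on the series, on what has been measured and on what is new or still open speak of the compounds shown alone.

Measured in a functional assay on PC-3 cells (Homo sapiens) for cytotoxicity, read by MTT assay, with a stated time of 96 h; on this read-out higher numbers stand for weaker inhibition and lower numbers for stronger inhibition:
- compound 1 `CC[C@H](NC)C(=O)N[C@@H]1C(=O)N2[C@@H](CC[C@@H]1CN)CC[C@H]2C(=O)NC(c1ccccc1)c1ccccc1`: 51700 nM
- compound 2 `CC[C@H](NC)C(=O)N[C@@H]1C(=O)N2[C@@H](CC[C@@H]1CCNC(=O)NCc1ccccc1)CC[C@H]2C(=O)NC(c1ccccc1)c1ccccc1`: 83500 nM

Within the data shown here, compound 2 stands level with compound 1, the only other measured compound, and the two values lie within the scatter of each other. The next structure is compound 3 `CCNCC[C@H]1CC[C@H]2CC[C@@H](C(=O)NC(c3ccccc3)c3ccccc3)N2C(=O)[C@H]1NC(=O)[C@H](CC)NC`, reached from compound 2 by ethyl in place of benzylcarbamoyl on an amine nitrogen. In words, this is ethyl in place of benzylcarbamoyl on an amine nitrogen. Among the measured compounds shown here, only one measured step bears on this change: a 1.6-fold higher number from compound 1 to compound 2 (0.21 log units; within the scatter). That step also involves the benzylcarbamoyl group, though the chain changes too, so it is an indirect guide and rests on a single pair. Since it stayed within the scatter, no step beyond the scatter is expected in this assay, and no direction can be called with confidence. The expected step is a 1.4-fold lower number from compound 2 to compound 3 (0.14 log units; within the scatter). For compound 3 the estimated value is 60000 nM, with an expected range of 25000 nM to 130000 nM.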

Compound 3, half-maximal inhibitory concentration: > 100000 nM
Compound 3: a limit, no number; the forecaster's own chance of this, stated with the estimate: 15%; at least 1.6-fold (0.22 log units) between middle value and limit.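

In this assay compound 3 gives > 100000 nM, a limit of the assay and not a number. Only floors can be read, an at least 1.1-fold higher number from compound 2 to compound 3 (0.07 log units; that floor lies within the scatter), and an at least 1.9-fold higher number from compound 1 to compound 3 (0.28 log units; that floor lies within the scatter), so the full size of neither step is settled. New at this amine nitrogen is that ethyl, with no ring and no hydrogen-bond donor or acceptor, gives no sign of stronger inhibition than benzylcarbamoyl, and that the series here reaches the end of the measurable range: the limit of > 100000 nM in this assay, at which 1 of the 3 values shown sits.

Open, from the compounds shown here alone, is whether an acetyl group, a sulfonamide or a longer alkyl chain on this amine nitrogen would give a value under the limit. Also open, going by these compounds, is whether any group at this position can move the value beyond the scatter in either direction.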